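The source may hold more compounds than are shown below. What is called first, only, known or untested is meant among the compounds shown, and "the series" means these compounds.

Measured so far:

- compound 1, `CCC(C)C(C(=O)Nc1ccc(C(C)=O)cc1)N(C(=O)c1ccccc1)S(=O)(=O)c1ccc(C)cc1`: 41.1%
- compound 2, `CC(=O)c1ccc(NC(=O)CN(C(=O)c2ccccc2)S(=O)(=O)c2ccccc2)cc1`: 40.9%

In a functional assay for inhibition, read by spectrophotometry, with a stated time of 20 min, tested at 4 mg/mL (a lower number here means a weaker effect, a higher number a stronger effect of the compound at the concentration tested), compound 1 gives 41.1% and compound 2 gives 40.9%. The two numbers lie within the scatter of each other, so neither compound can be placed above the other; compound 2 has the smaller of the two numbers by a margin that means nothing. For the measured compounds named here, no single-change step between measured compounds is available, and compound 1 differs from compound 2 in more than one place, so the share of each difference in the outcome is not known.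

Compound 3, `CCC(C)C(C(=O)Nc1ccc(C(C)=O)cc1)N(C(=O)c1ccccc1)S(=O)(=O)c1ccccc1`, is not yet measured. It differs from compound 2 by sec-butyl in place of hydrogen on a saturated chain carbon bound to an amide-type nitrogen and a carbonyl carbon. The same sec-butyl is already present in compound 1, which in this assay gives a number indistinguishable from compound 2. On that basis no step beyond the scatter is expected in this assay in either direction, and the step of a number 0.1 percentage points higher from compound 2 to compound 3 (within the scatter) is estimated as essentially flat. Compound 3 is therefore expected to give about 41%, with a range of 30% to 52%.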

Compound 3, a percentage reported as inhibition, at one concentration (the size of the read-out at that concentration, not a potency): 15.5%
Compound 3: middle estimate off by 25.5 percentage points, on the high side; the whole stated range lies above it.
By their numbers in this assay, from the lowest: compound 3; then compounds 2 and 1 (each within the scatter of the next).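

In this assay, sec-butyl in place of hydrogen on a saturated chain carbon bound to an amide-type nitrogen and a carbonyl carbon gives a number 25.4 percentage points lower from compound 2 to compound 3 (beyond the scatter), so this position is not indifferent to substitution when the aromatic carbon carries hydrogen. With sec-butyl in place, hydrogen in place of methyl on an aromatic carbon gives a number 25.6 percentage points lower from compound 1 to compound 3 (beyond the scatter), so that single methyl also counts in this series, and compound 3 lies beyond the scatter below both of its one-place neighbours. For the compounds shown here, nothing measured so far accounts for either step.

Going by these compounds, it remains open whether the step at the chain carbon belongs to sec-butyl in particular or would also follow from a smaller methyl, an isopropyl or a benzyl group there. On these data alone, it is equally open whether a chlorine or a methoxy group in place of the methyl on the aromatic carbon would give a number like that of compound 1 or one like that of compound 3.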